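Fluoro for Methyl on a Benzamide Kinase Inhibitor

The source may hold more compounds than are shown below. What is called first, only, known or untested is meant among the compounds shown, and "the series" means these compounds.

Measured compounds:
compound 1, `CC(=O)c1ccc(OCC(=O)Nc2cccc(NC(=O)c3ccc(N(C)C)cc3)c2)cc1F`: 445 nM
compound 2, `Cc1ccc(C(=O)Nc2cccc(NC(=O)COc3ccc4c(=O)ccoc4c3)c2)cc1`: 183 nM

Of the compounds shown here, two have been measured in an assay on isolated protein for inhibition of Rho-associated protein kinase 1 (Homo sapiens), read by scintillation counting, radiometric assay and 33P incorporation, with a stated time of 40 min, in the presence of a further agent that is not named here; a lower number here means a stronger inhibitor, a higher number a weaker inhibitor. Compound 1 gives 445 nM, while compound 2 gives 183 nM. Compound 2 thus has the lower of the two numbers, and its gap to compound 1 lies beyond the usual scatter of repeated measurements, so compound 2 is the stronger inhibitor of the pair.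

Compound 3, `O=C(COc1ccc2c(=O)ccoc2c1)Nc1cccc(NC(=O)c2ccc(F)cc2)c1`, differs from compound 2 in a single place: fluoro in place of methyl on an aromatic carbon. Among the compounds with values here, no pair of measured compounds shows this kind of exchange, so there is no measured step to lean on. A swap of one small group for another of the same size is expected to move the number only a little, in either direction, most likely not beyond the scatter. Compound 3 is therefore estimated at 250 nM, with a range from 90 nM to 700 nM. This estimate means an expected step of a 1.4-fold higher number from compound 2 to compound 3 (0.14 log units; within the scatter).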

Compound 3, half-maximal inhibitory concentration: 129 nM
Estimate against measurement, compound 3: 1.9-fold (0.29 log units) above; the range from low to high includes it.
By their numbers in this assay, from the lowest: compounds 3 and 2 (each within the scatter of the next); then compound 1.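

Exchanging 4-methylphenyl for 4-fluorophenyl gives a 1.4-fold lower number from compound 2 to compound 3 (0.15 log units; within the scatter) in this assay, so the two compounds cannot be told apart in this measurement. Within the data shown here, this is the first measured step at this position, on the benzamide ring and para to a large group, and it shows that fluoro can take the place of methyl here with no change that stands clear of the scatter. Nothing measured alongside these numbers speaks to what lies behind this result.

The compounds shown leave open whether a carboxylic acid, a primary amine or a longer chain such as butyl in the same place would also leave the number within the scatter. They also leave open whether fluoro for methyl would give a similarly small step on a different ring of the molecule.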